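Growth inhibition notes: from compound 2 to compound 3

The source may report more compounds than this note shows. Statements on the series, on what has been measured and on what is new or still open speak of the compounds shown alone.

Values so far in a functional assay on Caco-2 cells (Homo sapiens) for inhibition, read by MTT assay, with a stated time of 48 h, tested at 10 uM; on this read-out higher numbers stand for more inhibition of growth at the one concentration tested and lower numbers for less inhibition of growth
- compound 1 `Cc1cc(=O)c2c(O)c(CN3CCC(c4ccccc4)CC3)c(O)c([C@H]3CCN(C)C[C@H]3O)c2o1` gives 21%
- compound 2 `CCOC(=O)N1CCN(Cc2c(O)c([C@H]3CCN(C)C[C@H]3O)c3oc(C)cc(=O)c3c2O)CC1` gives 18%
- compound 3 `Cc1cc(=O)c2c(O)c(CN3CCCCC3)c(O)c([C@H]3CCN(C)C[C@H]3O)c2o1` is not yet measured

Compound 2 (at 18%) stands within the usual scatter of compound 1 (at 21%), so the two cannot be ranked, and both show only modest inhibition of growth at the single concentration tested.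

Compound 3 differs from compound 2 by one change (piperidin-1-yl in place of 4-(ethoxycarbonyl)piperazin-1-yl on a saturated chain carbon bound to an aromatic carbon): piperidin-1-yl in place of 4-(ethoxycarbonyl)piperazin-1-yl on a saturated chain carbon bound to an aromatic carbon.

Within the data shown here, no pair of measured compounds differs in one place only, so the data give no direct measure of what a single change does in this assay here. Among the measured compounds shown here, the only guide is that compound 1 (at 21%) and compound 2 (at 18%) lie within scatter of each other, so no step beyond the scatter is expected. The expected change is a number 2 percentage points higher from compound 2 to compound 3 (within the scatter) in this assay and remains an estimate. Compound 3 is estimated at 20% (expected range 8% to 35%).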

Compound 3, percent growth inhibition at one concentration: 22%
Compound 3: middle estimate off by 2 percentage points, on the low side; measured number inside the range.
By their numbers in this assay, from the lowest: compounds 2, 1 and 3 (each within the scatter of the next).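

In this assay, among these compounds, the swap at this place, a saturated chain carbon bound to an aromatic carbon, of 4-(ethoxycarbonyl)piperazin-1-yl with its 11 heavy atoms for piperidin-1-yl with 6 gives a number 4 percentage points higher from compound 2 to compound 3 (within the scatter) and so gives the first direct reading of a single change here, one that shows no shift that can be told from scatter. The second single change, hydrogen in place of phenyl on a saturated ring carbon, gives a number 1 percentage points higher from compound 1 to compound 3 (within the scatter) and shows likewise that the phenyl group on the piperidine ring makes no readable difference at the one concentration tested. Neither step can be assigned a cause, as no supporting measurement bears on these results.

From the compounds shown here alone, whether any group at this place moves growth inhibition beyond the scatter stays open, for instance a carboxylic acid or a primary amine on the saturated ring carbon, or a longer chain between the ring nitrogen and the aromatic carbon. The three compounds also leave open whether the shared core itself sets the modest level of inhibition seen in all of them.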